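Swapping the aryl group on the shared core

The source may hold more compounds than are shown below. What is called first, only, known or untested is meant among the compounds shown, and "the series" means these compounds.

Compound 1 `Cc1ccccc1Cn1cc(COc2ccc3c(=O)ccoc3c2)nn1` in a functional assay on QGY7701 cells (Homo sapiens) for cytotoxicity, read by MTT assay, with a stated time of 48 h (on this read-out higher numbers stand for weaker inhibition and lower numbers for stronger inhibition), gives > 100000 nM, which is a limit of the assay rather than a number.
Compound 2 `O=c1ccoc2cc(OCc3cn(Cc4ccc(Cl)cc4Cl)nn3)ccc12` in this assay gives 13300 nM.

Compound 2 holds the only number shown; the other value is a limit. Compound 3 `COc1ccc(Cn2cc(COc3ccc4c(=O)ccoc4c3)nn2)cc1` differs from compound 2 by 4-methoxyphenyl in place of 2,4-dichlorophenyl on a saturated chain carbon bound to an aromatic nitrogen. Among the measured compounds shown here, the one measured step at this place, an at least 7.5-fold lower number from compound 1 to compound 2 (0.87 log units; beyond the scatter), is the only evidence bearing on the change, and it shows that swapping the aryl group here moves the read-out by a sizeable amount; the limit of > 100000 nM in this assay, at which 1 of the 2 values shown sits, means its true size is not known. Compound 3 carries neither the 2,4-dichlorophenyl of compound 2 nor the 2-methylphenyl of compound 1, so the direction is uncertain, but a step back toward weaker inhibition, a 3.0-fold higher number from compound 2 to compound 3 (0.48 log units; beyond the scatter), is the expectation. Compound 3 is therefore estimated at 40000 nM, with a range of 10000 nM to 150000 nM, and a fair chance of only a limit.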

Compound 3, half-maximal inhibitory concentration: 56600 nM
Beside the measured number, compound 3's estimate is 1.4-fold (0.15 log units) below it; the range from low to high includes it.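

The step of a 4.3-fold higher number from compound 2 to compound 3 (0.63 log units; beyond the scatter) shows in this assay that the value at this place depends on more than the presence of an aryl ring: 4-methoxyphenyl gives back much of what 2,4-dichlorophenyl gained. Against 2-methylphenyl, the step reads an at least 1.7-fold lower number from compound 1 to compound 3 (0.24 log units; that floor lies within the scatter), so the compounds shown do not establish a real gain for 4-methoxyphenyl. Compound 1 holds a limit rather than a number, so that step is only a floor: the limit of > 100000 nM in this assay, at which 1 of the 3 values shown sits.

Among the three compounds, 2,4-dichlorophenyl gives the strongest inhibition, but the change from compound 2 removes both chlorine atoms and adds a methoxy group at once, so the share of each stays unknown. A 4-chlorophenyl group would help separate these parts, while a ring bearing an amine or a carboxylic acid remains an open question at this place.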